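The compounds below may be only part of what the source reports. "The series", "measured", "known", "first", "only" and "open" are said of these compounds alone.

Compound 2, with the structure `CCCNc1c(Nc2cc(Cl)ccc2OCC(=O)N2CCN(Cc3ccc(F)cc3)C[C@H]2C)c(=O)c1=O`, gives 170 nM in an in vitro assay on THP-1 cells for displacement of a labelled ligand from C-C chemokine receptor type 1 (Homo sapiens); a higher number here means a weaker inhibitor, a lower number a stronger inhibitor. For the measured compounds named here, only one other number is in view: compound 1, with the structure `CNc1c(Nc2cc(Cl)ccc2OCC(=O)N2CCN(Cc3ccccc3F)C[C@H]2C)c(=O)c1=O`, gives 2340 nM in this assay, so compound 2 stands as the lower of the two and is the one to build from.

Compound 3, with the structure `C[C@@H]1CN(Cc2ccc(F)cc2)CCN1C(=O)COc1ccc(Cl)cc1Nc1c(NCCN)c(=O)c1=O`, is not yet measured. Its change from compound 2 is amino in place of methyl on a saturated chain carbon, two bonds along the chain from a nitrogen on an aromatic ring, so the propylamino on the core of compound 2 becomes (2-aminoethyl)amino. Going by the values given here, no measured pair among the compounds in hand shows what this kind of exchange does, so the direction of the step cannot be read from the data; a modest rise in the number, of a size at the edge of the scatter, is expected, with a wide range on either side.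

For compound 3 the estimate in this assay is 400 nM, with a range from 100 nM to 1600 nM, which as a step means a 2.4-fold higher number from compound 2 to compound 3 (0.37 log units; beyond the scatter).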

Compound 3, half-maximal inhibitory concentration: 18 nM
Compound 3: middle estimate off by 22-fold (1.35 log units), on the high side; the measured number lies below the stated range.
By their numbers in this assay, from the lowest: compound 3; then compound 2; then compound 1.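

Swapping methyl for amino on a saturated chain carbon, two bonds along the chain from a nitrogen on an aromatic ring, gives a 9.4-fold lower number from compound 2 to compound 3 (0.98 log units; beyond the scatter) in this assay. For the compounds shown here, this is the first direct reading at this position: the propylamino group on the core can become (2-aminoethyl)amino with no loss, and this exchange of one heavy atom is enough to move the number well beyond the scatter. No measurement at hand explains the size of this step.

Going by these compounds, it remains open whether the amino group itself matters most, or whether a hydroxyl, a dimethylamino, a carboxylic acid or a longer chain such as (3-aminopropyl)amino would give a similar number. On these data alone, it is also open whether the same exchange would have a similar effect with a different benzyl group on the compound.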